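The source may hold more compounds than are shown below. What is called first, only, known or untested is meant among the compounds shown, and "the series" means these compounds.

In a functional assay on HepG2 cells (Homo sapiens) for antiproliferative activity, read by MTT assay (on this read-out lower numbers stand for stronger inhibition and higher numbers for weaker inhibition), compound 1 (`CCc1ccccc1-n1cc(COc2ccc(/C=C/C(=O)c3cc4c(cc3O)OC(C)(C)CC4)cc2)nn1`) gives 115000 nM and compound 2 (`CC1(C)CCc2c(ccc(C(=O)/C=C/c3ccc(OCc4cn(-c5ccc(Cl)cc5)nn4)cc3)c2O)O1`) gives 102000 nM, so the two compounds stand level, within the scatter of each other. Compound 3 (`CCc1ccccc1-n1cc(COc2ccc(/C=C/C(=O)c3ccc4c(c3O)CCC(C)(C)O4)cc2)nn1`) keeps the core of compound 2 and carries 2-ethylphenyl in place of 4-chlorophenyl on an aromatic nitrogen. Compound 1 also bears 2-ethylphenyl and gives 115000 nM, so no change beyond the scatter is expected in this assay. The expected step, a 1.0-fold higher number from compound 2 to compound 3 (0.01 log units; within the scatter), is therefore small. For compound 3 the estimated value is 105000 nM, with an expected range of 50000 nM to 200000 nM.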

Compound 3, half-maximal inhibitory concentration: 67800 nM
Compound 3: the middle estimate sits 1.5-fold (0.19 log units) above what was measured; low and high end bracket the measured number.
By their numbers in this assay, from the lowest: compounds 3, 2 and 1 (each within the scatter of the next).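

At this place on the aromatic nitrogen, 2-ethylphenyl in place of 4-chlorophenyl gives a 1.5-fold lower number from compound 2 to compound 3 (0.18 log units; within the scatter) in this assay. Within the data shown here, this is the first direct comparison at this position, and it shows the two groups standing level on this core. Nothing available explains this result. Still open, as far as these compounds go, is whether an amine or a carboxylic acid on the phenyl ring, or a plain methyl in place of that ring, would move the number beyond the scatter.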